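Estimating Clearance After Trimming a Tert-Butyl Group

A few compounds are considered here, and "the series" means these few. Any claim that something is new, unique, unknown or untested is made for them only; others in the source may bear on it.

Clearance in a living rat shows how quickly the body removes a compound, and here the numbers are sparse. In an ADME assay on the whole organism (Rattus norvegicus) for pharmacokinetics (on this read-out higher numbers stand for fast clearance and lower numbers for slow clearance), compound 1 (`COc1ccccc1C1C(C(=O)C(C)(C)C)=C(O)C(=O)N1c1ccc(-c2ccon2)cc1`) gives 1.3 mL/min/kg as its result, the only figure available. Compound 2 (`COc1ccccc1C1C(C(=O)C(C)(C)C)=C(O)C(=O)N1c1ccc(-c2ccsc2)cc1`) has no single number, and its entry reads "not determined" (no result reported) in the record. Compound 3 (`CN(C)C(=O)COc1ccccc1C1C(C(=O)C(C)(C)C)=C(O)C(=O)N1c1ccc(-c2ccsc2)cc1`) is the one further entry without a number, reading "not determined" (no result reported) as well. Compound 2 therefore offers no measured starting point.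

Compound 4 (`COc1ccccc1C1C(C(=O)C(C)C)=C(O)C(=O)N1c1ccc(-c2ccsc2)cc1`) differs from compound 2 in one place, tert-butyl to isopropyl, counted as hydrogen in place of methyl on a saturated chain carbon bound to a carbonyl carbon and two saturated chain carbons and read as hydrogen in place of methyl on a saturated chain carbon bound to a carbonyl carbon and two saturated chain carbons. Among the compounds with values here, no measured step of this kind exists in the data, so the expected size is a judgement. I expect a small upward step at most in this assay, not clearly beyond the usual scatter. Within the data shown here, the only anchor is compound 1 at 1.3 mL/min/kg in the same read-out, so the estimate stays in the low range and is kept wide. For compound 4 the expected clearance is 2.5 mL/min/kg as a middle estimate, with an estimated range from 0.8 mL/min/kg to 8 mL/min/kg around it.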

Compound 4, clearance: 0.3 mL/min/kg
The estimate for compound 4 lay 8.3-fold (0.92 log units) above the measured number; the whole stated range lies above it.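

No new step can be read from compound 4: in this assay its one-place neighbour, compound 2, has no single number to set it against. The compounds shown leave open whether going from tert-butyl to isopropyl shifts clearance at all, and by how much. Nothing shown offers an explanation for the result of compound 4.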